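Benzyl for 2-cyclohexylethyl: half-life notes

The compounds below may be only part of what the source reports. "The series", "measured", "known", "first", "only" and "open" are said of these compounds alone.

In an in vitro ADME assay on microsomes from liver (Homo sapiens) for metabolic stability, tested at 5 uM (on this read-out higher numbers stand for a longer-lived compound and lower numbers for a shorter-lived compound), compound 1 `CCC(C)n1nc(-c2cccs2)c(O)c(C2=NS(=O)(=O)c3cc(NS(C)(=O)=O)ccc3N2)c1=O` gives > 1 h, a limit and not a number. Compound 2 `CS(=O)(=O)Nc1ccc2c(c1)S(=O)(=O)N=C(c1c(O)c(-c3cccs3)nn(CCC3CCCCC3)c1=O)N2` gives > 1 h, also a limit. Both compounds sit at the limit of > 1 h in this assay, at which 2 of the 2 values shown sit. Among the measured compounds shown here, the only measured step is a step that the two limits leave unreadable from compound 1 to compound 2, with 2-cyclohexylethyl in place of sec-butyl on an aromatic nitrogen. Compound 3 `CS(=O)(=O)Nc1ccc2c(c1)S(=O)(=O)N=C(c1c(O)c(-c3cccs3)nn(Cc3ccccc3)c1=O)N2` differs from compound 2 by phenyl in place of cyclohexylmethyl on a saturated chain carbon bound to an aromatic nitrogen. For the measured compounds named here, no measured step gives a size to carry over. The estimated step in this assay is a step that the limit leaves unreadable from compound 2 to compound 3, with no direction expected. For compound 3 the expected half-life is 1.5 h, with an estimated range of 0.7 h to 3 h.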

Compound 3, half-life: > 1 h
Compound 3 ended at the assay's limit; the forecaster's own chance of this, stated with the estimate: 75%; the middle value is on the limit's open side.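

No step can be read among compound 1, compound 2 and compound 3 in this assay, as all three values are one limit and not numbers: the limit of > 1 h in this assay, at which 3 of the 3 values shown sit.

The compounds shown leave open whether the half-lives with sec-butyl, 2-cyclohexylethyl and benzyl differ at all.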